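The source may report more compounds than this note shows. Statements on the series, on what has been measured and on what is new or still open speak of the compounds shown alone.

Compounds measured in an ADME assay on MT4 cells (Homo sapiens) for cytotoxicity, read by MTT assay (on this read-out higher numbers stand for lower toxicity in this test and lower numbers for higher toxicity in this test), so far:
- compound 1 `Cc1ccc(N(C(=O)c2ccccc2[N+](=O)[O-])C(=S)OCCN2C(=O)c3ccccc3C2=O)cc1`: 100000 nM
- compound 2 `Cc1ccc(C(=O)N(C(=S)OCCN2C(=O)c3ccccc3C2=O)c2ccc(C)cc2)cc1`: 83000 nM
- compound 3 `O=C1c2ccccc2C(=O)N1CCOC(=S)N(C(=O)c1cccc(F)c1F)c1ccc(Cl)cc1`: 58000 nM

All three numbers sit within the usual scatter of one another, so compound 3 is not set apart from compound 1 or compound 2 on this read-out.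

Compound 4 `Cc1cc(C(=O)N(C(=S)OCCN2C(=O)c3ccccc3C2=O)c2ccc(Cl)cc2)c(C)o1` is the next case. Its difference from compound 3: 2,5-dimethylfuran-3-yl in place of 2,3-difluorophenyl on a carbonyl carbon

Going by the values given here, the only step on record that also changes the group on the carbonyl carbon is a 1.2-fold lower number from compound 1 to compound 2 (0.08 log units; within the scatter), and it did not move the number beyond the scatter. That step exchanges one six-membered aromatic ring for another; the present change brings in a five-membered ring with one hetero atom, so the bearing is loose. Nothing in the series points to a shift, and compound 4 is expected to stay close to compound 3, with an estimated step of a 1.0-fold higher number from compound 3 to compound 4 (0.01 log units; within the scatter).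

Estimated for compound 4: 60000 nM, range 25000 nM to 140000 nM.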

Compound 4, half-maximal cytotoxic concentration: 40000 nM
The estimate for compound 4 lay 1.5-fold (0.18 log units) above the measured number; low and high end bracket the measured number.
By their numbers in this assay, from the lowest: compounds 4, 3, 2 and 1 (each within the scatter of the next, the first and the last beyond it).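

On the carbonyl carbon, in this assay, the five-membered 2,5-dimethylfuran-3-yl ring with its one hetero atom replaces the six-membered, carbon-only 2,3-difluorophenyl ring, giving a 1.5-fold lower number from compound 3 to compound 4 (0.16 log units; within the scatter). The position therefore tolerates a change of ring size and the loss of both fluorines without leaving the scatter, which the earlier exchange between six-membered aromatic rings could not show. No measurement at hand offers an explanation for this outcome.

Still open, going by these compounds, is whether a group of another kind on this carbonyl carbon, such as an amine, a carboxylic acid or a longer alkyl chain, would move the number beyond the scatter. Also open, on these data alone, is whether 2,5-dimethylfuran-3-yl would give a similar step on the core of compound 2.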